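The compounds below may be only part of what the source reports. "The series", "measured", "known", "first", "only" and "open" are said of these compounds alone.

Compound 1 `O=C(CCSc1nc2cc(Cl)ccc2o1)N1CCCCC1` carries a piperidin-1-yl on its carbonyl carbon and, in an ADME assay on microsomes from liver (Homo sapiens) for metabolic stability, read by LC-MS, using NADPH, with a stated time of 45 min, tested at 0.5 uM (a lower number here means slower removal, a higher number faster removal of the compound), compound 1 gives 10.7 mL/min/g. Compound 2 `CN1CCN(C(=O)CCSc2nc3cc(Cl)ccc3o2)CC1` replaces that ring with 4-methylpiperazin-1-yl and in this assay compound 2 gives 1.5 mL/min/g, which is a 7.1-fold lower number from compound 1 to compound 2 (0.85 log units; beyond the scatter). Compound 3 `O=C(CCSc1nc2cc(Cl)ccc2o1)N1CCS(=O)(=O)C1`, with a 1,1-dioxo-1,3-thiazolidin-3-yl on the carbonyl carbon, gives 1.7 mL/min/g in this assay, a change of a 6.3-fold lower number from compound 1 to compound 3 (0.80 log units; beyond the scatter). Compound 2 thus stands at the low end of the three numbers, with compound 1 furthest from it, while compound 3 is a 1.1-fold higher number from compound 2 to compound 3 (0.05 log units; within the scatter) and so cannot be separated from it.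

Compound 4 `CS(=O)(=O)N1CCN(C(=O)CCSc2nc3cc(Cl)ccc3o2)CC1` differs from compound 2 by methylsulfonyl in place of methyl on an amine nitrogen in a ring. Among the measured compounds shown here, no measured step alters a group on that ring nitrogen; the only step that keeps a polar amide partner in place, from compound 2 to compound 3, stayed within the scatter. Compound 4 is therefore expected to give 1.8 mL/min/g in this assay, within a range from 0.9 mL/min/g to 3.6 mL/min/g. That expected outcome corresponds to a 1.2-fold higher number from compound 2 to compound 4 (0.08 log units; within the scatter), a step not anticipated to exceed the scatter.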

Compound 4, intrinsic clearance in a liver preparation (reported as CLH), per the amount of preparation that the assay uses: 0.6 mL/min/g
Estimate against measurement, compound 4: 3.0-fold (0.48 log units) above, and the stated range ends above it.
By their numbers in this assay, from the lowest: compound 4; then compounds 2 and 3 (each within the scatter of the next); then compound 1.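

Among the compounds shown here, the ring nitrogen, which no earlier step had altered, proves to be a position where a single change moves the number in this assay: methylsulfonyl in place of methyl on that amine nitrogen in a ring gives a 2.5-fold lower number from compound 2 to compound 4 (0.40 log units; beyond the scatter). The earlier exchange of one whole amide ring for another, a 1.1-fold higher number from compound 2 to compound 3 (0.05 log units; within the scatter), gave no such separation, so the low end of the series can still shift through a change to the group on this nitrogen alone. Nothing available here accounts for this step.

The compounds shown leave open whether the shift is particular to methylsulfonyl or would also appear with an acetyl or an ethylsulfonyl on the same nitrogen. They also leave open how this position behaves with only a hydrogen on that nitrogen.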